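The source may report more compounds than this note shows. Statements on the series, on what has been measured and on what is new or still open speak of the compounds shown alone.

Measured in a functional assay on HepG2 cells (Homo sapiens) for cytotoxicity, read by MTT assay, with a stated time of 72 h; a lower number here means a stronger inhibitor, a higher number a weaker inhibitor:
- compound 1 `CNC(=O)c1cc(Oc2ccc(C3=NNC(c4ccc(Cl)cc4Cl)C3)cc2)ccn1`: "not determined" (no result reported)
- compound 2 `CNC(=O)c1cc(Oc2ccc(C3=NNC(c4ccc(C#N)cc4)C3)cc2)ccn1`: 15000 nM
- compound 3 `CNC(=O)c1cc(Oc2ccc(C3=NNC(c4ccc(OC)cc4)C3)cc2)ccn1`: 9640 nM

In this assay compound 3 gives 9640 nM and compound 2 gives 15000 nM, two numbers that lie within the scatter of each other. For the measured compounds named here, compound 1 offers no number to compare, so compound 3 has only one measured neighbour.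

The next compound, compound 4 `CNC(=O)c1cc(Oc2ccc(C3=NNC(c4ccccc4)C3)cc2)ccn1`, has hydrogen in place of methoxy on an aromatic carbon, turning 4-methoxyphenyl into phenyl: hydrogen in place of methoxy on an aromatic carbon. Going by the values given here, only one measured step bears on this change, and it is a 1.6-fold lower number from compound 2 to compound 3 (0.19 log units; within the scatter). That step put methoxy in place of cyano on an aromatic carbon and stayed within the scatter. Among the compounds with values here, it is thin evidence, and no measured compound yet carries hydrogen there. Even so, no step beyond the scatter is expected.

The expected step is a 1.2-fold higher number from compound 3 to compound 4 (0.10 log units; within the scatter). For compound 4 the estimate is 12000 nM, with an expected range from 5000 nM to 28000 nM.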

Compound 4, half-maximal inhibitory concentration: 1500 nM
Beside the measured number, compound 4's estimate is 8.0-fold (0.90 log units) above it; the whole stated range lies above it.
By their numbers in this assay, from the lowest: compound 4; then compounds 3 and 2 (each within the scatter of the next).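

In this assay, hydrogen in place of methoxy gives a 6.4-fold lower number from compound 3 to compound 4 (0.81 log units; beyond the scatter) and hydrogen in place of cyano gives a 10-fold lower number from compound 2 to compound 4 (1.00 log units; beyond the scatter) on the same aromatic carbon. The position therefore does respond to change, which the comparison of methoxy with cyano alone could not show. Among these three compounds, the two with a group on this carbon sit within the scatter of each other, and the one with only hydrogen stands clearly apart, yet no measurement here explains that gap.

The compounds shown leave open whether a small group such as fluorine or methyl on this carbon would read like compound 4 or like compound 3, and what an amine or a carboxylic acid there would do. Compound 1 has no reported result, so its chlorines add nothing to this picture.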